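The source may report more compounds than this note shows. Statements on the series, on what has been measured and on what is new or still open speak of the compounds shown alone.

Working notes on the series.

Three compounds share one core and differ only in the group on the amide-type nitrogen. Compound 1 `Cn1cc(NC(=O)c2ccncc2Nc2cc(-c3ccc4ccn(C)c4c3)c3nccnc3c2)cn1` gives 33 nM in an assay for inhibition of 6-phosphofructo-2-kinase/fructose-2,6-bisphosphatase 3 (Homo sapiens), read by ADP-Glo, with a stated time of 2 h; a higher number here means a weaker inhibitor, a lower number a stronger inhibitor. Compound 2 `CN1CCC(NC(=O)c2ccncc2Nc2cc(-c3ccc4ccn(C)c4c3)c3nccnc3c2)CC1=O` gives 41 nM in this assay. Compound 3 `CC(=O)N1CCCC(NC(=O)c2ccncc2Nc2cc(-c3ccc4ccn(C)c4c3)c3nccnc3c2)C1` gives 11 nM in this assay, the lowest of the three numbers. The step of a 3.0-fold lower number from compound 1 to compound 3 (0.48 log units; beyond the scatter) and the step of a 3.7-fold lower number from compound 2 to compound 3 (0.57 log units; beyond the scatter) both lie beyond the scatter, whereas the step of a 1.2-fold higher number from compound 1 to compound 2 (0.09 log units; within the scatter) does not; so far compound 3 stands apart from the other two.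

Compound 4 `CC(=O)N1CC(CNC(=O)c2ccncc2Nc2cc(-c3ccc4ccn(C)c4c3)c3nccnc3c2)C1` is not yet measured. It differs from compound 3 in one place: (1-acetylazetidin-3-yl)methyl in place of 1-acetylpiperidin-3-yl on an amide-type nitrogen. For the measured compounds named here, both measured steps that bear on this position, a 3.0-fold lower number from compound 1 to compound 3 (0.48 log units; beyond the scatter) and a 3.7-fold lower number from compound 2 to compound 3 (0.57 log units; beyond the scatter), were modest in size, and neither of them exchanged a six-membered ring for a four-membered ring with a methylene between ring and nitrogen, so there is no direct precedent for this particular change. Given that every change at this position so far moved the number by only a modest amount, a small shift is expected, if any, most likely a somewhat higher number than compound 3 because compound 3 already holds the lowest value at 11 nM. For compound 4 the expected step is a 2.0-fold higher number from compound 3 to compound 4 (0.30 log units; within the scatter). The estimate for compound 4 in this assay is 22 nM, with a range from 8 nM to 60 nM.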

Compound 4, half-maximal inhibitory concentration: 137 nM
Compound 4: middle estimate off by 6.2-fold (0.79 log units), on the low side; the whole stated range lies below it.
By their numbers in this assay, from the lowest: compound 3; then compounds 1 and 2 (each within the scatter of the next); then compound 4.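

In this assay, the step of a 12-fold higher number from compound 3 to compound 4 (1.10 log units; beyond the scatter) is the only large one at this position, so the group on the amide-type nitrogen is less forgiving than the modest earlier steps suggested, and exchanging 1-acetylpiperidin-3-yl for (1-acetylazetidin-3-yl)methyl is enough to show it. Compound 4 also separates from the other two compounds, with a 3.3-fold higher number from compound 2 to compound 4 (0.52 log units; beyond the scatter) and a 4.2-fold higher number from compound 1 to compound 4 (0.62 log units; beyond the scatter), so compound 3 and compound 4 stand at opposite ends of the four numbers although both groups carry an acetyl, and the acetyl alone therefore does not set the number. Nothing measured here accounts for the size of this step.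

This change alters the ring size and adds a methylene in a single exchange, so the compounds shown do not tell which of the two carries the step; a 1-acetylazetidin-3-yl or a (1-acetylpiperidin-3-yl)methyl group on the same nitrogen would separate them. Also open, from the compounds shown here alone, is how the number responds when the acetyl on either ring is replaced by a free ring amine or by a longer acyl chain such as propanoyl.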